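From 4-Methylphenyl to 4-Chlorophenyl in a Cytotoxicity Series

The source may report more compounds than this note shows. Statements on the series, on what has been measured and on what is new or still open speak of the compounds shown alone.

compound 1 `C=C1C[C@]23C[C@@]1(O)CC[C@H]2c1cc(Br)c(O)c(C)c1[C@@H]3Cn1cc(-c2ccccc2)nn1`: > 20000 nM
compound 2 `C=C1C[C@]23C[C@@]1(O)CC[C@H]2c1cc(Br)c(O)c(C)c1[C@@H]3Cn1cc(-c2ccc(C)cc2)nn1`: > 20000 nM

In a functional assay on A549 cells (Homo sapiens) for cytotoxicity, read by MTT assay, with a stated time of 4 days (a higher number here means a weaker inhibitor, a lower number a stronger inhibitor), compound 1 gives only a limit, > 20000 nM. In this assay compound 2 likewise gives only a limit, > 20000 nM. The step that the two limits leave unreadable from compound 1 to compound 2 therefore cannot be read, because both values sit at the limit of > 20000 nM in this assay, at which 2 of the 2 values shown sit. Compound 3, `C=C1C[C@]23C[C@@]1(O)CC[C@H]2c1cc(Br)c(O)c(C)c1[C@@H]3Cn1cc(-c2ccc(Cl)cc2)nn1`, differs from compound 2 by chloro in place of methyl on an aromatic carbon. Among the compounds with values here, the one measured step touches the same place but gives no readable size, and compound 2 itself stands at the limit. Compound 3 is thus expected to show a step that the limit leaves unreadable from compound 2 to compound 3, most likely again a limit, with an estimate of 25000 nM ranging from 8000 nM to 80000 nM.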

Compound 3, half-maximal inhibitory concentration: 10500 nM
Beside the measured number, compound 3's estimate is 2.4-fold (0.38 log units) above it; the range from low to high includes it.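

In this assay, within the data shown here, chloro on this aromatic carbon, para to a large group, gives compound 3 the only value shown that is a number and not a limit, with an at least 1.9-fold lower number from compound 2 to compound 3 (0.27 log units; that floor lies within the scatter) and an at least 1.9-fold lower number from compound 1 to compound 3 (0.27 log units; that floor lies within the scatter). Both steps are only floors, because compound 1 and compound 2 each sit at a limit: the limit of > 20000 nM in this assay, at which 2 of the 3 values shown sit. The position therefore responds to at least this one change, though the true size of that response cannot be read. Going by these compounds, whether bromo, methoxy or an amine at this place would also give a number remains open, as does any difference between hydrogen and methyl there.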